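A Ring Group Exchanged on a Shared Core

The source may hold more compounds than are shown below. What is called first, only, known or untested is meant among the compounds shown, and "the series" means these compounds.

Compound 1 `CC(C)C(/C=C1\NC(=O)NC1=O)c1ccc(-c2ccc3cccc(F)c3c2)[nH]c1=O`: 7500 nM
Compound 2 `CC(C)C(/C=C1\SC(=O)NC1=O)c1ccc(-c2ccc3cccc(F)c3c2)[nH]c1=O`: 4800 nM
Compound 3 `CC(C)C(CC1NC(=O)NC1=O)c1ccc(-c2ccc3cccc(F)c3c2)[nH]c1=O`: not yet measured

In a physicochemical assay for solubility, measured as kinetic solubility, at pH 2 (a lower number here means a less soluble compound, a higher number a more soluble compound), compound 2 gives 4800 nM. Within the data shown here, only two numbers are available so far, and they lie within the scatter of each other: the step is a 1.6-fold lower number from compound 1 to compound 2 (0.19 log units; within the scatter). Compound 3 keeps the shared core and changes one group: a group of 8 heavy atoms (4 carbon, 2 nitrogen, 2 oxygen; one five-membered non-aromatic ring with 2 hetero atoms) in place of a group of 8 heavy atoms (4 carbon, 1 nitrogen, 2 oxygen, 1 sulfur; one five-membered non-aromatic ring with 2 hetero atoms), on a saturated chain carbon bound to an aromatic carbon and a saturated chain carbon. The entering group is (2,5-dioxoimidazolidin-4-yl)methyl, and it sits on a saturated chain carbon bound to an aromatic carbon and a saturated chain carbon.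

Among the measured compounds shown here, only the step from compound 1 to compound 2 bears on this change. It acted at the same place, and the group in compound 1 has the same heavy-atom make-up as the entering group. For the measured compounds named here, that step stayed within the scatter, but no measured compound carries the entering group itself, so the evidence is thin. No step beyond the scatter is therefore expected in this assay, and the estimated step is a 1.5-fold higher number from compound 2 to compound 3 (0.16 log units; within the scatter). The wide range reflects that thin evidence. Compound 3 is estimated at 7000 nM, with an expected range of 2500 nM to 20000 nM.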

Compound 3, solubility: 13000 nM
Compound 3: middle estimate off by 1.9-fold (0.27 log units), on the low side; low and high end bracket the measured number.
By their numbers in this assay, from the lowest: compounds 2, 1 and 3 (each within the scatter of the next, the first and the last beyond it).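

In this assay, the exchange at this saturated chain carbon, bound to an aromatic carbon and a saturated chain carbon, now gives a step beyond the scatter, which the earlier pair did not: a 2.7-fold higher number from compound 2 to compound 3 (0.43 log units; beyond the scatter). That exchange alters two things at once, as the leaving group holds sulfur and one more double bond outside aromatic rings, while (2,5-dioxoimidazolidin-4-yl)methyl holds a second nitrogen, and the other two steps stay smaller: the step of a 1.7-fold higher number from compound 1 to compound 3 (0.24 log units; within the scatter) and the earlier step of a 1.6-fold lower number from compound 1 to compound 2 (0.19 log units; within the scatter) both lie within the scatter, so only the two end compounds of the series stand apart. No measured property is available to account for the step beyond the scatter.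

The compounds shown leave open how much of the step belongs to the change of ring atom and how much to the change in double bonds, as no compound pairs sulfur in the ring with the form that has fewer double bonds. They also leave open whether an amine, a carboxylic acid or a longer chain at this place would move the number further than (2,5-dioxoimidazolidin-4-yl)methyl does.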